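Series notes: aryl variation and a pending sulfonamide analogue

The source may hold more compounds than are shown below. What is called first, only, known or untested is meant among the compounds shown, and "the series" means these compounds.

Measured so far:
compound 1 `Oc1cccc2cc(-c3ccccc3)ccc12`, 20%
compound 2 `Oc1cccc2cc(-c3ccncc3)ccc12`, 26%
compound 3 `Oc1cccc2cc(-c3ccoc3)ccc12`, 13%

Three compounds have been run in an assay for binding affinity to 17-beta-hydroxysteroid dehydrogenase type 2 (Homo sapiens), with a stated time of 20 min, tested at 1 uM; a lower number here means less inhibition, a higher number more inhibition at the concentration tested (going by the name of the read-out). Compound 1 gives 20%; its number sits between that of compound 2 and that of compound 3, and both of those lie within the scatter of it, so the three cannot be ranked with confidence.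

Compound 4 `CNS(=O)(=O)c1ccc(-c2ccc3c(O)cccc3c2)cc1` is not yet measured. Against compound 1 the change is methylsulfamoyl in place of hydrogen on an aromatic carbon. Going by the values given here, no measured pair shows this change, so nothing in the data sets its size; the working expectation is a modest upward step, possibly not beyond the scatter. Compound 4 is estimated to give 32% in this assay, with a range of 8% to 60%. That estimate implies an expected step of a number 12 percentage points higher from compound 1 to compound 4 (beyond the scatter).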

Compound 4, a percentage reported as inhibition, at one concentration (the size of the read-out at that concentration, not a potency): 57%
Compound 4: the middle estimate sits 25 percentage points below what was measured; low and high end bracket the measured number.
By their numbers in this assay, from the lowest: compounds 3, 1 and 2 (each within the scatter of the next, the first and the last beyond it); then compound 4.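

Methylsulfamoyl in place of hydrogen on an aromatic carbon, para to a large group, gives a number 37 percentage points higher from compound 1 to compound 4 (beyond the scatter). Compounds 1, 2 and 3 vary only the aryl ring and carry no substituent on it; compound 4 shows that this position accepts a substituent and that the read-out responds strongly to this change. Nothing available bears on the reason for a step of this size.

Going by these compounds, whether the step depends on the methylsulfamoyl group in particular remains open. A plain sulfamoyl, a carboxylic acid or a methoxy group at the same place would test this.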